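Bromo-to-chloro exchange on the arylidene ring of compound 1

This account rests on a few compounds, and the source may have more. Where it says the series, first, only, none or still open, it means among the compounds named here.

Working notes on the series. Going by the values given here, compound 1 `O=C1/C(=C\c2cccc(Br)c2)c2ccccc2N1c1c(Cl)cccc1Cl` is one of two compounds measured in a functional assay on L132 cells (Homo sapiens) for cytotoxicity, read by MTT assay, with a stated time of 72 h (on this read-out lower numbers stand for an effect already at smaller amounts and higher numbers for an effect only at larger amounts of compound), and in this assay compound 1 gives 19 ug/mL, the lower of the two numbers. Compound 2 `Cc1ccc2nc(Cl)c(/C=C3\C(=O)N(c4c(Cl)cccc4Cl)c4ccccc43)cc2c1C` is the other measured compound; in this assay compound 2 gives 98 ug/mL, a number that lies beyond the scatter from that of compound 1. Among the compounds with values here, no pair of measured compounds differs in a single place, so no step of one change has been seen in this set.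

Compound 3 `O=C1/C(=C\c2cccc(Cl)c2)c2ccccc2N1c1c(Cl)cccc1Cl` has not yet been measured. It differs from compound 1 in one place: chloro in place of bromo on an aromatic carbon. Within the data shown here, with no measured step of this kind to lean on, the step of a 1.3-fold higher number from compound 1 to compound 3 (0.12 log units; within the scatter) is estimated to lie within the usual scatter, in no particular direction. Compound 3 is therefore expected to give about 25 ug/mL in this assay, with an estimated range from 10 ug/mL to 60 ug/mL.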

Compound 3, concentration for half-maximal effect: 16 ug/mL
Estimate against measurement, compound 3: 1.6-fold (0.19 log units) above; measured number inside the range.
By their numbers in this assay, from the lowest: compounds 3 and 1 (each within the scatter of the next); then compound 2.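

In this assay the set now holds its first step of one change, and a 1.2-fold lower number from compound 1 to compound 3 (0.07 log units; within the scatter) shows that chloro in place of bromo on this aromatic carbon leaves the number within the scatter. For this assay, the 3-bromophenyl and 3-chlorophenyl forms can therefore be treated as equivalent, an observation limited to this one pair on the core of compound 1. No measurement bearing on why the two halogens read alike is at hand.

Still open, from the compounds shown here alone, is how this place responds to groups other than these two halogens, such as fluoro, methoxy, an amine or a carboxylic acid, or to plain hydrogen. Also open, going by these compounds, is whether the same exchange would stay within the scatter on another core.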